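Turning the double bond of compound 3 from E to Z

A few compounds are considered here, and "the series" means these few. Any claim that something is new, unique, unknown or untested is made for them only; others in the source may bear on it.

Compound 1 `FC(F)(F)Oc1ccc(/C=C/c2ccc3ccccc3c2)cc1`: > 5000 nM, a limit
Compound 2 `Cc1ccc(/C=C\c2ccc3ccccc3c2)cc1`: > 5000 nM, a limit
Compound 3 `FC(F)(F)c1ccc(/C=C/c2ccc3ccccc3c2)cc1`: > 5000 nM, a limit

In a functional assay on A549 cells (Homo sapiens) for inhibition (a higher number here means a weaker inhibitor, a lower number a stronger inhibitor), compound 3 gives > 5000 nM, which is a limit and not a number. The whole set rests on (the limit of > 5000 nM in this assay, at which 3 of the 3 values shown sit). Compound 4 `FC(F)(F)c1ccc(/C=C\c2ccc3ccccc3c2)cc1` has not been measured. Set against compound 3, the change is this: the two compounds have the same atoms and bonds and differ only in configuration as drawn: 1 of 1 stereo elements differ; a double bond is drawn E in compound 3 and Z in compound 4. The nearest measured change is a step that the two limits leave unreadable from compound 1 to compound 3, and it concerns another place in the molecule. Compound 2 also has its double bond drawn Z, and compound 2 gives > 5000 nM, again a limit. No readable change in this assay is therefore expected, in either direction. The expected step is a step that the limit leaves unreadable from compound 3 to compound 4, and another limit is the likeliest report. For compound 4 the estimated value is 6000 nM, with an expected range from 2000 nM to 15000 nM.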

Compound 4, half-maximal inhibitory concentration: > 5000 nM
Compound 4: only a limit was reported; the forecaster's own chance of this, stated with the estimate: 75%; the middle value is on the limit's open side.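

Neither the step from compound 3 to compound 4 nor that from compound 2 to compound 4 can be read, as all three compounds give only a limit. The compounds shown leave open whether double-bond configuration affects inhibition at all.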